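Swapping a pyridine for a methylphenyl on the tetrazole

The compounds below may be only part of what the source reports. "The series", "measured", "known", "first", "only" and "open" are said of these compounds alone.

Of the compounds shown here, three have been measured in an assay on HEK293 cells for activation of Kir3.1/Kir3.2 (Homo sapiens), read by thallium flux; on this read-out lower numbers stand for an effect already at smaller amounts and higher numbers for an effect only at larger amounts of compound. Compound 1 `Cc1cc(NC(=O)Cn2nnc(-c3ccccc3)n2)n(Cc2ccccc2)n1` gives 495 nM in this assay. Compound 2 `O=C(Cn1nnc(-c2ccccc2)n1)Nc1ccccn1` is reported in this assay as "not active" (no number reported), with no number attached. Compound 3 `Cc1cc(NC(=O)Cn2nnc(-c3cccnc3)n2)n(C2CCCCC2)n1` gives 1930 nM in this assay, the highest of the two numbers shown; compound 1 sits at a lower number, and the gap between them lies beyond the usual scatter. Compound 1 and compound 3 differ in more than one place, so their two values can only be set side by side, not read as a single step.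

Compound 4 `Cc1ccc(-c2nnn(CC(=O)Nc3cc(C)nn3C3CCCCC3)n2)cc1` has not yet been measured. It differs from compound 3 in one place: 4-methylphenyl in place of pyridin-3-yl on an aromatic carbon. Going by the values given here, no single-change step exists among the measured compounds to guide this change directly. Among the compounds with values here, the step of a 2.4-fold lower number from compound 3 to compound 4 (0.38 log units; beyond the scatter) is expected to be a modest lowering of the number, because compound 1, the only other compound with a number, gives 495 nM. Compound 4 is therefore estimated to give 800 nM, with a range from 250 nM to 2500 nM.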

Compound 4, half-maximal effective concentration: 111 nM
Beside the measured number, compound 4's estimate is 7.2-fold (0.86 log units) above it; measured number outside the range, below it.
By their numbers in this assay, from the lowest: compound 4; then compound 1; then compound 3.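

Going by these compounds alone, this is the first single-change step in the set, and it shows that the group on this aromatic carbon of the five-membered aromatic ring with 4 nitrogen matters in this assay: 4-methylphenyl in place of pyridin-3-yl brings a 17-fold lower number from compound 3 to compound 4 (1.24 log units; beyond the scatter). The change removes a ring nitrogen, counted as a hydrogen-bond acceptor, and adds a methyl group in the same step, so the step alone cannot say which part carries the shift. No measurement shown gives a reason for its size.

Open, on these data alone, is how phenyl without the methyl group would read on the core of compound 4, which would separate the two parts of the change. Also open, as far as these compounds go, is whether other groups at this place, such as 4-chlorophenyl or 4-methoxyphenyl, would give lower or higher numbers.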